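Fluorinated nitrophenyl swap on a tert-butyl-protected analogue

A few compounds are considered here, and "the series" means these few. Any claim that something is new, unique, unknown or untested is made for them only; others in the source may bear on it.

Compound 1 `Nc1nc(N)c(CCCN(Cc2ccc(NC(CCC(=O)O)C(=O)O)cc2)c2ccc([N+](=O)[O-])c(F)c2F)c(O)n1` and compound 2 `Nc1nc(N)c(CCCN(Cc2ccc(NC(CCC(=O)O)C(=O)O)cc2)c2cc(F)ccc2[N+](=O)[O-])c(O)n1` share a core and differ only where (2,3-difluoro-4-nitrophenyl in place of 5-fluoro-2-nitrophenyl on an amine nitrogen). In a functional assay on CCRF-CEM cells (Homo sapiens) for cytotoxicity, in the absence of a further agent (on this read-out lower numbers stand for stronger inhibition and higher numbers for weaker inhibition), compound 2 reaches only the limit > 100000 nM. Compound 1 likewise reaches only the limit > 100000 nM. The step that the two limits leave unreadable from compound 2 to compound 1 is therefore not readable, since the limit of > 100000 nM in this assay, at which 2 of the 3 values shown sit, holds both values. Compound 3 `CC(C)(C)OC(=O)CCC(Nc1ccc(CN(CCCc2c(N)nc(N)nc2O)c2cc(F)ccc2[N+](=O)[O-])cc1)C(=O)OC(C)(C)C` stands on a different core, and the difference between the two cores is not broken down here; in this assay compound 3 gives 8700 nM. Compound 4 `CC(C)(C)OC(=O)CCC(Nc1ccc(CN(CCCc2c(N)nc(N)nc2O)c2ccc([N+](=O)[O-])c(F)c2F)cc1)C(=O)OC(C)(C)C` is the same change made on compound 3, described by 2,3-difluoro-4-nitrophenyl in place of 5-fluoro-2-nitrophenyl on an amine nitrogen, with an identical place. With the measured pair unreadable, the step from compound 3 to compound 4 is expected to be near nil, a 1.1-fold higher number from compound 3 to compound 4 (0.06 log units; within the scatter). Compound 4 is thus estimated at 10000 nM, within 3000 nM to 40000 nM.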

Compound 4, half-maximal inhibitory concentration: 24000 nM
The estimate for compound 4 lay 2.4-fold (0.38 log units) below the measured number; measured number inside the range.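

In this assay, 2,3-difluoro-4-nitrophenyl in place of 5-fluoro-2-nitrophenyl on an amine nitrogen gives a 2.8-fold higher number from compound 3 to compound 4 (0.44 log units; beyond the scatter) on the core of compound 3. On the core of compound 1 the same change cannot be read, since compound 1 and compound 2 both stand at a limit of the assay and not at a number: the limit of > 100000 nM in this assay, at which 2 of the 4 values shown sit. The step is thus seen on one core only, and nothing here shows whether its size or direction carries over to the other core.

Still open, as far as these compounds go, is how the amine nitrogen tolerates other groups, such as unsubstituted phenyl. Also open, from the compounds shown here alone, is whether a methyl ester in place of the tert-butyl esters of compound 3 and compound 4 would shift the read-out.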